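The source may report more compounds than this note shows. Statements on the series, on what has been measured and on what is new or still open speak of the compounds shown alone.

Of the compounds shown here, three that share one core have been tested in an assay on HEK293 cells for activation of Kir3.1/Kir3.2 (Homo sapiens), read by thallium flux (a lower number here means that less compound is needed, a higher number that more compound is needed for the effect), so far. Compound 3 `Cc1cc(NC(=O)Cn2nnc(-c3cccc(Cl)c3)n2)n(C2CCCCC2)n1` gives 300 nM in this assay, the lowest of the two numbers reported. Compound 1 `Cc1cc(NC(=O)Cn2nnc(-c3ccccc3)n2)n(-c2ccccc2)n1` gives 3020 nM in this assay, a number a full order higher than that of compound 3 and well beyond the usual scatter of such measurements. Compound 2 `O=C(Cn1nnc(-c2ccccc2)n1)Nc1ccccn1` is reported in this assay only as "not active" (no number reported), with no number attached, so it cannot be placed on the same scale as the other two.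

The next compound, compound 4 `COc1cccc(-c2nnn(CC(=O)Nc3cc(C)nn3C3CCCCC3)n2)c1`, differs from compound 3 in a single place: methoxy in place of chloro on an aromatic carbon. The rest of the molecule, the cyclohexyl and the amide-linked core, is kept unchanged. For the measured compounds named here, no pair of already-measured compounds shows this same exchange, so there is no measured step to lean on. Because compound 3 already stands at 300 nM and the exchange is small, the step from compound 3 to compound 4 is expected to be modest, roughly a 2.0-fold higher number from compound 3 to compound 4 (0.30 log units; within the scatter) toward a somewhat higher number, if it rises above the scatter at all. Compound 4 is therefore estimated at 600 nM in this assay, within a range from 200 nM to 2000 nM.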

Compound 4, half-maximal effective concentration: 117 nM
Estimate against measurement, compound 4: 5.1-fold (0.71 log units) above; the measured number lies below the stated range.
By their numbers in this assay, from the lowest: compound 4; then compound 3; then compound 1.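

In this assay, for the compounds shown here, exchanging chloro for methoxy on this aromatic carbon gives a 2.6-fold lower number from compound 3 to compound 4 (0.41 log units; beyond the scatter), the first measured step that changes only one place. It shows that chloro is not needed at this carbon: the 3-methoxyphenyl compound needs less compound for the effect, even though methoxy brings two heavy atoms in place of one and a hydrogen-bond acceptor that chloro lacks. No measurement here explains why this exchange lowers the number.

The compounds shown leave open which feature of methoxy matters, the oxygen or the carbon beyond it; a hydroxyl or a methyl group on the same carbon would help to separate the two, and an ethoxy group would show whether a longer chain is accepted there. They also leave open whether the same exchange would give a similar step with a group other than cyclohexyl kept elsewhere in the molecule, so this single step cannot yet be treated as a general rule for the series.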